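The compounds below may be only part of what the source reports. "The series", "measured", "known", "first", "only" and "open" are said of these compounds alone.

Measured so far:
- compound 1, `CCCOC(=O)/C=C/c1ccc(NC(=O)C2(NC(=O)c3ccc4c(C5CCCC5)c(-c5ncc(Cl)cn5)n(C)c4c3)CCC2)cc1OCC`: 0.35 h
- compound 2, `CCOc1cc(NC(=O)C2(NC(=O)c3ccc4c(C5CCCC5)c(-c5ncc(Cl)cn5)n(C)c4c3)CCC2)ccc1/C=C/C(=O)OCC(Cl)(Cl)Cl`: 0.233 h
- compound 3, `CCOc1cc(NC(=O)C2(NC(=O)c3ccc4c(C5CCCC5)c(-c5ncc(Cl)cn5)n(C)c4c3)CCC2)ccc1/C=C/C(=O)OCc1ccccc1`: 2.17 h

In an ADME assay (liver) for pharmacokinetics, with Liver microsome (Rattus norvegicus) as the target, using microsomes (on this read-out lower numbers stand for a shorter-lived compound and higher numbers for a longer-lived compound), compound 1 gives 0.35 h, the second highest of the three numbers. Its nearest neighbour is compound 2, at a 1.5-fold lower number from compound 1 to compound 2 (0.18 log units; within the scatter), and its furthest is compound 3, at a 6.2-fold higher number from compound 1 to compound 3 (0.79 log units; beyond the scatter). Compound 4, `CCCN(C)C(=O)COC(=O)/C=C/c1ccc(NC(=O)C2(NC(=O)c3ccc4c(C5CCCC5)c(-c5ncc(Cl)cn5)n(C)c4c3)CCC2)cc1OCC`, is compound 1 with a single change: methyl(propyl)carbamoyl in place of ethyl on a saturated chain carbon bound to an oxygen next to a carbonyl group. All three measured compounds differ from one another only at this same place, so the steps among them are the relevant guide. Swapping ethyl for trichloromethyl left the number within the scatter, whereas swapping it for phenyl raised it modestly, and from compound 2 to compound 3 the move was a 9.3-fold higher number from compound 2 to compound 3 (0.97 log units; beyond the scatter). For the measured compounds named here, the group entering in compound 4 matches neither of those, so the measured steps only show that a replacement at this position can leave the number essentially unchanged or lift it modestly, with no example of a large fall. The expectation for compound 4 in this assay is therefore a step of a 1.4-fold higher number from compound 1 to compound 4 (0.15 log units; within the scatter), within the scatter, with some chance of a modest rise. Compound 4 is expected to give 0.5 h, in a range from 0.2 h to 1.5 h.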

Compound 4, half-life: 0.317 h
For compound 4 the middle estimate is 1.6-fold (0.20 log units) above the measured one; measured number inside the range.
By their numbers in this assay, from the lowest: compounds 2, 4 and 1 (each within the scatter of the next); then compound 3.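

In this assay, a much larger group now sits on the saturated chain carbon bound to an oxygen next to a carbonyl group: methyl(propyl)carbamoyl, with 7 heavy atoms including a nitrogen and an oxygen, enters where ethyl, with 2 heavy atoms, leaves, and this gives a 1.1-fold lower number from compound 1 to compound 4 (0.04 log units; within the scatter) and shows that this added bulk and these extra atoms need not separate the two compounds on this read-out. The comparison with the trichloromethyl compound gives a 1.4-fold higher number from compound 2 to compound 4 (0.13 log units; within the scatter) and places compounds 1, 2 and 4 together, so three quite different groups at this position cannot be told apart here. The comparison with the phenyl compound gives a 6.8-fold lower number from compound 3 to compound 4 (0.84 log units; beyond the scatter) and leaves compound 3 as the only one of the four that stands apart, which makes phenyl, not simply any larger group, the exception in this small set.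

The compounds shown leave open whether that longer half-life belongs to phenyl alone or extends to other rings at this position, such as pyridyl, cyclohexyl or a chlorophenyl. Nothing given here explains why phenyl differs from the other three groups.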